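Ring size at the amine and adenosine receptor A3 binding

The compounds below may be only part of what the source reports. "The series", "measured", "known", "first", "only" and "open" are said of these compounds alone.

This account compares four close relatives that share one core and differ only in the group on a nitrogen on an aromatic ring. Compound 1 `CNC(=O)[C@H]1O[C@@H](n2cnc3c(N)nc(Cl)nc32)[C@H](O)[C@@H]1O` carries hydrogen there; in an assay on CHO cells for displacement of a labelled ligand from adenosine receptor A3 (Homo sapiens) (a lower number here means a stronger inhibitor, a higher number a weaker inhibitor), compound 1 gives 0.398 nM. Compound 2 `CNC(=O)[C@H]1O[C@@H](n2cnc3c(NC)nc(Cl)nc32)[C@H](O)[C@@H]1O` carries methyl and in this assay compound 2 gives 0.282 nM. Compound 3 `CNC(=O)[C@H]1O[C@@H](n2cnc3c(NC4CC4)nc(Cl)nc32)[C@H](O)[C@@H]1O` carries cyclopropyl, and in this assay compound 3 gives 2.24 nM, the highest of the three numbers.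

Two of the measured steps bear on how the nitrogen substituent is tolerated: a 1.4-fold lower number from compound 1 to compound 2 (0.15 log units; within the scatter), and a 5.6-fold higher number from compound 1 to compound 3 (0.75 log units; beyond the scatter). The third, a 7.9-fold higher number from compound 2 to compound 3 (0.90 log units; beyond the scatter), points the same way. Small groups are tolerated, but a ring already costs affinity.

Compound 4 `CNC(=O)[C@H]1O[C@@H](n2cnc3c(NC4CCCC4)nc(Cl)nc32)[C@H](O)[C@@H]1O` goes one step further: cyclopentyl in place of cyclopropyl on a nitrogen on an aromatic ring. Within the data shown here, no measured pair shows a cyclopentyl here, so the expectation rests on the direction already seen from hydrogen and methyl to cyclopropyl. The larger ring is expected to push the number up further, an estimated 3.6-fold higher number from compound 3 to compound 4 (0.55 log units; beyond the scatter). Compound 4 is therefore estimated at 8 nM in this assay, with an expected range from 2 nM to 40 nM.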

Compound 4, inhibition constant: 4.27 nM
Compound 4: the middle estimate sits 1.9-fold (0.27 log units) above what was measured, within the range that was stated.
By their numbers in this assay, from the lowest: compounds 2 and 1 (each within the scatter of the next); then compounds 3 and 4 (each within the scatter of the next).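

The step from cyclopropyl to cyclopentyl on a nitrogen on an aromatic ring (a 1.9-fold higher number from compound 3 to compound 4 (0.28 log units; within the scatter)) shows that in this assay these two rings cannot be told apart, so among the compounds shown, the larger ring adds no measurable cost beyond the smaller one. What compound 4 adds is a wider gap from the two small substituents: measured against methyl (a 15-fold higher number from compound 2 to compound 4 (1.18 log units; beyond the scatter)) and against hydrogen (an 11-fold higher number from compound 1 to compound 4 (1.03 log units; beyond the scatter)), both steps are large and beyond the scatter, and all four compounds fall into two pairs, with compound 1 and compound 2 on one side and the two ring compounds on the other. Nothing in the material shown accounts for this grouping or says why the two rings read so closely.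

The compounds shown leave open whether a cyclohexyl group or an open chain such as isopropyl on this nitrogen would sit with the two rings or with hydrogen and methyl in this assay. They also leave open how a benzyl group, or a cyclopentyl ring carrying a hydroxyl or an amine, would fare at this place.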